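From 4-methylphenyl to butyl on the triple bond

The source may hold more compounds than are shown below. What is called first, only, known or untested is meant among the compounds shown, and "the series" means these compounds.

In a functional assay on CCRF-CEM cells (Homo sapiens) for antiproliferative activity, read by MTT assay, with a stated time of 3 days (on this read-out higher numbers stand for weaker inhibition and lower numbers for stronger inhibition), compound 1 `Cc1ccc(C#Cc2cn(C/C=C\CN3C(=O)c4ccccc4C3=O)c(=O)[nH]c2=O)cc1` gives 238000 nM as the highest of the three measured numbers. Compound 2 `CCCCCCC#Cc1cn(C/C=C/CN2C(=O)c3ccccc3C2=O)c(=O)[nH]c1=O` gives 28000 nM and compound 3 `CCCCCc1ccc(C#Cc2cn(C/C=C/CN3C(=O)c4ccccc4C3=O)c(=O)[nH]c2=O)cc1` gives 23000 nM with the other double-bond geometry. Compound 4 `CCCCC#Cc1cn(C/C=C\CN2C(=O)c3ccccc3C2=O)c(=O)[nH]c1=O` keeps the geometry of compound 1 and differs from it as butyl in place of 4-methylphenyl on a triple-bonded carbon counts: butyl in place of 4-methylphenyl on a triple-bonded carbon. Within the data shown here, the one measured step at that carbon is a 1.2-fold lower number from compound 2 to compound 3 (0.09 log units; within the scatter) and stays within the scatter, though it runs from chain to ring under the other geometry. No step beyond the scatter is therefore expected, and the estimated change is a 1.4-fold lower number from compound 1 to compound 4 (0.15 log units; within the scatter) for this swap. For compound 4 the estimate is 170000 nM with an expected range from 55000 nM to 450000 nM once it is measured.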

Compound 4, half-maximal inhibitory concentration: 100000 nM
The estimate for compound 4 lay 1.7-fold (0.23 log units) above the measured number; low and high end bracket the measured number.
By their numbers in this assay, from the lowest: compounds 3 and 2 (each within the scatter of the next); then compound 4; then compound 1.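

In this assay the change gives a 2.4-fold lower number from compound 1 to compound 4 (0.38 log units; beyond the scatter) and so moves the number beyond the scatter, which the earlier step at this triple-bonded carbon, a 1.2-fold lower number from compound 2 to compound 3 (0.09 log units; within the scatter) under the other double-bond geometry, did not do. A ring-to-chain swap at this carbon can therefore matter, at least with the geometry of compound 1. Nothing available accounts for this difference between 4-methylphenyl and butyl. As far as these compounds go, whether a chain bearing an amine or a carboxylic acid in place of butyl would lower the number further remains open, as does how butyl itself behaves under the other geometry.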